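The compounds below may be only part of what the source reports. "The series", "measured", "known", "first", "only" and "open" are said of these compounds alone.

Measured compounds:
Compound 1, `Cc1ccccc1CNC(=O)c1nc(-c2ccc(F)cc2)n(CC[C@@H](O)C[C@@H](O)CC(=O)O)c1C1CC1`, in an assay on microsomes from liver for inhibition of 3-hydroxy-3-methylglutaryl-coenzyme A reductase (Rattus norvegicus), read by scintillation counting, with stated times of 0.5 h and 0.75 h (a higher number here means a weaker inhibitor, a lower number a stronger inhibitor), compound 1 gives 4.9 nM.
Compound 2, `COc1cccc(CNC(=O)c2nc(-c3ccc(F)cc3)n(CC[C@@H](O)C[C@@H](O)CC(=O)O)c2C2CC2)c1`, in this assay compound 2 gives 1.2 nM.

Among the measured compounds shown here, compound 2 has the lowest of the two numbers in this assay; the one step to it, a 4.1-fold lower number from compound 1 to compound 2 (0.61 log units; beyond the scatter), lies beyond the scatter. Compound 3, `CN(C)S(=O)(=O)c1ccc(CNC(=O)c2nc(-c3ccc(F)cc3)n(CC[C@@H](O)C[C@@H](O)CC(=O)O)c2C2CC2)cc1`, is reached from compound 2 by 4-(dimethylsulfamoyl)phenyl in place of 3-methoxyphenyl on a saturated chain carbon bound to an amide-type nitrogen. For the measured compounds named here, the only measured step, a 4.1-fold lower number from compound 1 to compound 2 (0.61 log units; beyond the scatter), also exchanges one aryl group at the same place, but neither of those two aryl groups is the one entering here, so it tells the size that such an exchange can reach rather than its direction for this case. A step of modest size in either direction, or none beyond the scatter, is therefore the reasonable expectation in this assay. Compound 3 is expected to give 2.5 nM, with a range from 0.7 nM to 9 nM. The expected step is a 2.1-fold higher number from compound 2 to compound 3 (0.32 log units; beyond the scatter).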

Compound 3, half-maximal inhibitory concentration: 4.9 nM
The estimate for compound 3 lay 2.0-fold (0.29 log units) below the measured number; measured number inside the range.
By their numbers in this assay, from the lowest: compound 2; then compounds 1 and 3 (each within the scatter of the next).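

In this assay, 4-(dimethylsulfamoyl)phenyl in place of 3-methoxyphenyl gives a 4.1-fold higher number from compound 2 to compound 3 (0.61 log units; beyond the scatter), so this place can move the number upward by as much as the earlier step moved it downward. In place of 2-methylphenyl, the same group gives no change at the digits printed from compound 1 to compound 3 (within the scatter), so an aryl group with more heavy atoms and a sulfonamide-bearing substituent is accepted here without a difference from compound 1. Of the three aryl groups, only 3-methoxyphenyl, in compound 2, stands apart from the other two, beyond the scatter of both.

No measurement shown offers an explanation for these steps. Going by these compounds, whether the lower number of compound 2 comes from the methoxy group itself stays open, as does what an unsubstituted phenyl or a ring bearing an amine or a carboxylic acid would give at this place.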